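The source may report more compounds than this note shows. Statements on the series, on what has been measured and on what is new or still open speak of the compounds shown alone.

Measured in a functional assay on MDBK cells (Bos taurus) for cytotoxicity; on this read-out higher numbers stand for lower toxicity in this test and lower numbers for higher toxicity in this test:
- Compound 1 `Cc1ccc(O)c(C(=O)NCCCN2CCC[C@@H]3CCCC[C@@H]32)c1`: > 100 ug/mL
- Compound 2 `Cc1ccc(O)c(C(=O)NCCCN2CCC(C)[C@@H]3CCCC[C@@H]32)c1`: 100 ug/mL

The reading for compound 1, > 100 ug/mL, is a limit of the assay and not a number.

Compound 3 `Cc1ccc(O)c(C(=O)NCCCN2CCC[C@@H]3CCCC[C@H]32)c1` has the same atoms and bonds as compound 1 and differs only in configuration as drawn: the two compounds have the same atoms and bonds and differ only in configuration as drawn: 1 of 2 stereo elements differ; a stereocentre at a saturated ring carbon is drawn S in compound 1 and R in compound 3.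

Going by the values given here, only one step has been measured: a number no higher from compound 1 to compound 2 (the limit leaves the size open). That change is a methyl in place of hydrogen on a saturated ring carbon, not a change of configuration, and its size cannot be read. Among the compounds with values here, it therefore gives little guidance for compound 3, and no measured step points in either direction. The expected step is a number no higher from compound 1 to compound 3 (the limit leaves the size open), which means none beyond the scatter is expected.

Compound 3 is estimated at 100 ug/mL, with an expected range of 50 ug/mL to 200 ug/mL.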

Compound 3, half-maximal cytotoxic concentration: 60 ug/mL
Compound 3: middle estimate off by 1.7-fold (0.22 log units), on the high side; the measured number falls inside the stated range.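

In this assay, a change of configuration alone at a saturated ring carbon gives an at least 1.6-fold lower number from compound 1 to compound 3 (0.22 log units; that floor lies within the scatter). Compound 1 reads > 100 ug/mL, which is a limit of the assay and not a number. The step is therefore only a floor, and since that floor lies within the usual scatter, this pair does not settle whether the change of configuration matters for toxicity in this test, because the comparison rests on: the limit of > 100 ug/mL in this assay, at which 1 of the 3 values shown sits.

The compounds shown leave open what a change at the second stereocentre, drawn the same in compound 1 and compound 3, would do. They also leave open how this change of configuration would read with an ethyl group or a carboxylic acid on the saturated ring carbon that carries the methyl in compound 2.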